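Small Amide Swap, Uncertain Outcome

The source may report more compounds than this note shows. Statements on the series, on what has been measured and on what is new or still open speak of the compounds shown alone.

In a functional assay on MCF7 cells (Homo sapiens) for inhibition, read by MTT assay (on this read-out lower numbers stand for stronger inhibition of growth and higher numbers for weaker inhibition of growth), compound 3 `CC1=C(/C=C/C(C)=C/C=C/C(C)=C\C(=O)NCc2ccc(O)cc2)C(C)(C)CC=C1c1cncnc1` gives 4960 nM, within the scatter of compound 1 `CC1=C(/C=C/C(C)=C/C=C/C(C)=C\C(=O)Nc2cccc(F)c2)C(C)(C)CCC1n1ccnc1` at 5490 nM, while compound 2 `CC1=C(/C=C/C(C)=C/C=C/C(C)=C\C(=O)Nc2ccc(F)cc2)C(C)(C)CCC1n1ccnc1` stands far lower at 400 nM. Compound 4 `CC1=C(/C=C/C(C)=C/C=C/C(C)=C\C(=O)Nc2ccccc2)C(C)(C)CC=C1c1cncnc1` differs from compound 3 by carrying phenyl in place of 4-hydroxybenzyl on an amide-type nitrogen. For the measured compounds named here, the only measured step that bears on this change is large: a 14-fold lower number from compound 1 to compound 2 (1.14 log units; beyond the scatter), with 4-fluorophenyl in place of 3-fluorophenyl on that kind of nitrogen. That pair has a different core and no plain phenyl, so it warns of a wide range but sets no direction. The expected change in this assay is therefore slight, an estimated 1.7-fold lower number from compound 3 to compound 4 (0.22 log units; within the scatter), within the scatter. For compound 4 the estimated value is 3000 nM, with an expected range of 700 nM to 9000 nM.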

Compound 4, concentration for 50% growth inhibition: 7010 nM
Beside the measured number, compound 4's estimate is 2.3-fold (0.37 log units) below it; low and high end bracket the measured number.
By their numbers in this assay, from the lowest: compound 2; then compounds 3, 1 and 4 (each within the scatter of the next).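

The step of a 1.4-fold higher number from compound 3 to compound 4 (0.15 log units; within the scatter) shows that, on the core of compound 3, 4-hydroxybenzyl and phenyl on the amide-type nitrogen cannot be told apart in this assay. For the compounds shown here, the large gap between the two fluorophenyl compounds therefore has no counterpart in this pair, although that gap arose on a different core. No available evidence accounts for this result.

On these data alone, whether 4-fluorophenyl would give a lower number on the core of compound 4 remains open. So does the effect of a longer chain on the nitrogen, or of an amine or carboxylic acid on the phenyl ring.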